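The source may hold more compounds than are shown below. What is called first, only, known or untested is meant among the compounds shown, and "the series" means these compounds.

Measured so far in an assay on isolated protein for inhibition of Amine oxidase [flavin-containing] B (Homo sapiens); on this read-out lower numbers stand for stronger inhibition and higher numbers for weaker inhibition:

compound 1, `C#CCNC1CCc2c(SCCc3cccc(C)c3)cccc21`: 0.35 nM
compound 2, `C#CCNC1CCc2c(SCCc3cccc(C(F)(F)F)c3)cccc21`: 3720 nM
compound 3, `C#CCNC1CCc2c(SCc3ccc(C(F)(F)F)cc3)cccc21`: 9680 nM

Compounds 1 and 2 share a core and differ in one place: methyl in place of trifluoromethyl on an aromatic carbon. This single exchange gives an 11000-fold lower number from compound 2 to compound 1 (4.03 log units; beyond the scatter), so within this pair the methyl-bearing compound 1 gives by far the lower number. Compound 3 carries the trifluoromethyl as well, but the difference between its core and the core of compound 2 is not broken down here; what the values show is that compound 3 gives the highest number of the three measured compounds, and that its gap to compound 2 lies beyond the usual scatter.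

Compound 4, `C#CCNC1CCc2c(SCc3ccc(C)cc3)cccc21`, has not yet been measured. It stands to compound 3 as compound 1 stands to compound 2: methyl in place of trifluoromethyl on an aromatic carbon. The two places are not identical, however. In compound 1 the methyl sits meta to a large group, whereas in compound 4 it sits para to a large group, so this is the same kind of change rather than the same change.

A step like a 390-fold lower number from compound 3 to compound 4 (2.59 log units; beyond the scatter) is expected for compound 4, resting on the size of an 11000-fold lower number from compound 2 to compound 1 (4.03 log units; beyond the scatter) while allowing that the shift in place and the different core may temper it. Compound 4 is therefore estimated at 25 nM in this assay, with a range from 1.5 nM to 400 nM.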

Compound 4, half-maximal inhibitory concentration: 1560 nM
For compound 4 the middle estimate is 62-fold (1.80 log units) below the measured one; measured number outside the range, above it.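

In this assay, methyl in place of trifluoromethyl gives a 6.2-fold lower number from compound 3 to compound 4 (0.79 log units; beyond the scatter), so the change moves the number in the same direction on both cores, but its size does not carry over from one core to the other: the same change on two cores in this assay, an 11000-fold lower number (4.03 log units; beyond the scatter) from compound 2 to compound 1 and a 6.2-fold lower number (0.79 log units; beyond the scatter) from compound 3 to compound 4, 1700-fold (3.23 log units) apart, beyond the scatter of two such steps Across these two pairs, the methyl compound gives the lower number each time, yet the step seen on one core gives no reliable guide to the size of the step on the other. The pairs differ both in their core and in the place of the exchange, and the values cannot separate these two differences or explain why the step is so much larger in one pair than in the other.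

With only two pairs shown, it remains open whether the large step or the modest one is more typical of this exchange across the series. Also open, from the compounds shown here alone, is how other groups at these places, such as a chlorine atom, a methoxy group or a nitrile, would read in this assay, and whether the exchange would behave the same way on a core with a longer chain.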